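A few compounds are considered here, and "the series" means these few. Any claim that something is new, unique, unknown or untested is made for them only; others in the source may bear on it.

Measured so far:
compound 1, `Cc1ccc(NC(=O)Nn2c(-c3ccccc3)nc3ccccc3c2=O)cc1`: 54%
compound 2, `CCc1nc2ccccc2c(=O)n1NC(=O)Nc1ccc(C)cc1`: 55%
compound 3, `CCc1nc2ccccc2c(=O)n1NC(=O)Nc1ccc(OC)cc1`: 48%

In a functional assay on the whole organism (strain albino) with Mus musculus as the target, at a dose of 100 mg/kg by the intraperitoneal route (on this read-out lower numbers stand for less inhibition and higher numbers for more inhibition at the one dose given (going by the name of the read-out)), compound 1 stands second highest of the three numbers, and its gaps to compound 2 and to compound 3 both lie within the scatter. Going by the values given here, the only steps measured, a number 1 percentage points higher from compound 1 to compound 2 (within the scatter) and a number 7 percentage points lower from compound 2 to compound 3 (within the scatter), each stayed within the scatter. Compound 4, `Cc1ccccc1NC(=O)Nn1c(-c2ccccc2)nc2ccccc2c1=O`, is not yet measured. It differs from compound 1 by 2-methylphenyl in place of 4-methylphenyl on an amide-type nitrogen. Among the compounds with values here, neither measured step touches the amide-type nitrogen, so no step bears directly on this change; the two steps seen only show that single changes have so far stayed within the scatter. No step beyond the scatter is therefore expected in this assay. Compound 4 is estimated at 52%, range 32% to 70%, the expected step being a number 2 percentage points lower from compound 1 to compound 4 (within the scatter).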

Compound 4, a percentage reported as inhibition, in the whole organism at one dose (the size of the read-out at that dose, not a potency): 59%
Compound 4: middle estimate off by 7 percentage points, on the low side; the measured number falls inside the stated range.
By their numbers in this assay, from the lowest: compounds 3, 1, 2 and 4 (each within the scatter of the next, the first and the last beyond it).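

In this assay the first change measured on the amide-type nitrogen, 2-methylphenyl in place of 4-methylphenyl, gives a number 5 percentage points higher from compound 1 to compound 4 (within the scatter) and so adds this place to those where a single change has stayed within the scatter. At this one dose, the read-out does not separate these two methylphenyl groups on the core of compound 1. Nothing available explains the result.

Open, as far as these compounds go, is whether chloro or dimethylamino in place of the methyl on this phenyl ring would give a step beyond the scatter. Also open, from the compounds shown here alone, is whether 2-methylphenyl in place of 4-methylphenyl behaves the same way in compound 2, which carries ethyl instead of phenyl.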